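Lengthening the Hydroxycarbamoyl Arm of Compound 2

The compounds below may be only part of what the source reports. "The series", "measured", "known", "first", "only" and "open" are said of these compounds alone.

In a functional assay on U-937 cells (Homo sapiens) for inhibition, read by MTT assay, with a stated time of 48 h (on this read-out lower numbers stand for stronger inhibition and higher numbers for weaker inhibition), three compounds sharing one core have been measured. Compound 1 (`O=C(/C=C/COc1no[n+]([O-])c1S(=O)(=O)c1ccccc1)NO`) gives 48000 nM, compound 2 (`O=C(NO)c1ccc(Oc2no[n+]([O-])c2S(=O)(=O)c2ccccc2)cc1`) gives 4730 nM and compound 3 (`COc1cc(C(=O)NO)ccc1Oc1no[n+]([O-])c1S(=O)(=O)c1ccccc1`) gives 3640 nM. Compound 2 therefore lies well below compound 1 and level with compound 3 within the scatter. Compound 4 (`O=C(/C=C/c1ccc(Oc2no[n+]([O-])c2S(=O)(=O)c2ccccc2)cc1)NO`) has not yet been measured. Its difference from compound 2 is 2-(hydroxycarbamoyl)ethenyl in place of hydroxycarbamoyl on an aromatic carbon, which amounts to 2-(hydroxycarbamoyl)ethenyl in place of hydroxycarbamoyl on an aromatic carbon. The one measured step among these compounds is a 1.3-fold lower number from compound 2 to compound 3 (0.11 log units; within the scatter), from methoxy in place of hydrogen on an aromatic carbon, and it stays within the scatter. Among the measured compounds shown here, no measured pair isolates the exchange in compound 4, so this step is only a weak guide. A large shift in this assay is not expected, only a slight move towards a lower number that stays within the scatter. The estimated step is a 1.6-fold lower number from compound 2 to compound 4 (0.20 log units; within the scatter). For compound 4 the expected value is 3000 nM, with an estimated range of 800 nM to 12000 nM.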

Compound 4, half-maximal inhibitory concentration: 16100 nM
The estimate for compound 4 lay 5.4-fold (0.73 log units) below the measured number; the whole stated range lies below it.
By their numbers in this assay, from the lowest: compounds 3 and 2 (each within the scatter of the next); then compound 4; then compound 1.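

The step of a 3.4-fold higher number from compound 2 to compound 4 (0.53 log units; beyond the scatter) in this assay comes from 2-(hydroxycarbamoyl)ethenyl in place of hydroxycarbamoyl on an aromatic carbon, para to a large group. Unlike the methoxy exchange in compound 3, which stayed within the scatter, this change moves the number beyond the scatter, towards weaker inhibition. Among the compounds shown, this position therefore responds to the longer arm, and the direction is the opposite of a gain. Nothing at hand accounts for this shift. From the compounds shown here alone, whether the added length or the added double bond carries the change stays open, and a 2-(hydroxycarbamoyl)ethyl group at the same place would separate the two. Also open, going by these compounds, is how a carboxylic acid in place of the hydroxycarbamoyl group would read at this position.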